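From furan-2-yl to methyl(phenyl)amino on the carbonyl

A few compounds are considered here, and "the series" means these few. Any claim that something is new, unique, unknown or untested is made for them only; others in the source may bear on it.

Values so far in a functional assay on MKN-45 cells (Homo sapiens) for cytotoxicity; on this read-out higher numbers stand for weaker inhibition and lower numbers for stronger inhibition:
Compound 1 `COc1ccc(S(=O)(=O)N2CCc3cccc(NC(=O)Oc4ccccc4)c32)cc1` gives > 10000 nM as a limit of the assay
Compound 2 `COc1ccc(S(=O)(=O)N2CCc3cccc(NC(C)=O)c32)cc1` gives 61 nM
Compound 3 `COc1ccc(S(=O)(=O)N2CCc3cccc(NC(=O)c4ccco4)c32)cc1` gives 10.7 nM

Compound 3 holds the lowest number in the set, and compound 2 is its nearest neighbour on the scale. The entry for compound 1 is a limit and not a number. The next compound to consider is compound 4 `COc1ccc(S(=O)(=O)N2CCc3cccc(NC(=O)N(C)c4ccccc4)c32)cc1`, which carries methyl(phenyl)amino in place of furan-2-yl on a carbonyl carbon. Within the data shown here, no measured compound carries this group. Phenoxy in compound 1 is the closest measured comparison, since it too brings a six-membered aromatic ring of carbon only onto that carbonyl carbon. Replacing phenoxy gave large steps, with furan-2-yl (an at least 930-fold lower number from compound 1 to compound 3 (2.97 log units; beyond the scatter)) and with methyl (an at least 160-fold lower number from compound 1 to compound 2 (2.21 log units; beyond the scatter)). Exchanging methyl for furan-2-yl gave only a modest step (a 5.7-fold lower number from compound 2 to compound 3 (0.76 log units; beyond the scatter)). In this assay the expected change is therefore a large one towards a higher number (a 140-fold higher number from compound 3 to compound 4 (2.15 log units; beyond the scatter)). Methyl(phenyl)amino is not phenoxy, so the expected range stays wide, and a reading at the limit remains possible. The estimated value for compound 4 is 1500 nM, with an expected range from 100 nM to 10000 nM.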

Compound 4, half-maximal inhibitory concentration: > 10000 nM
Compound 4 was reported as a limit; the forecaster's own chance of this, stated with the estimate: 30%; middle value at least 6.6-fold (0.82 log units) away from the limit.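

In this assay, the change to methyl(phenyl)amino on the carbonyl carbon gives large steps from both measured compounds with a lower number, an at least 930-fold higher number from compound 3 to compound 4 (2.97 log units; beyond the scatter) and an at least 160-fold higher number from compound 2 to compound 4 (2.21 log units; beyond the scatter), so the large loss seen with phenoxy is not confined to that one group. Compound 4 gives > 10000 nM, which is a limit of the assay and not a number. Both groups bringing a six-membered aromatic ring of carbon only onto the carbonyl carbon now stand at this limit, while methyl and furan-2-yl do not and no compound shown goes against this, but the step between the two compounds at the limit cannot be read: the limit of > 10000 nM in this assay, at which 2 of the 4 values shown sit.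

The compounds shown do not separate the aromatic ring from the atom linking it to the carbonyl carbon, so phenyl attached directly, and dimethylamino or methoxy with no ring, would be the informative comparisons. On these data alone, it also remains open whether the furan-2-yl result extends to other five-membered aromatic rings such as thiophen-2-yl, or whether a six-membered ring containing nitrogen, such as pyridin-2-yl, would return to the range of compound 3.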